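Dimethylamino to bromo: the next step in the series

The source may hold more compounds than are shown below. What is called first, only, known or untested is meant among the compounds shown, and "the series" means these compounds.

In a functional assay on MCF7 cells (Homo sapiens) for inhibition, read by MTT assay, with a stated time of 48 h (on this read-out higher numbers stand for weaker inhibition and lower numbers for stronger inhibition), compound 1 (`Oc1ccc(C(c2c[nH]c3ccc(Br)cc23)c2c[nH]c3ccc(Br)cc23)cc1`) gives 3500 nM and compound 2 (`CN(C)c1ccc(C(c2c[nH]c3ccc(Br)cc23)c2c[nH]c3ccc(Br)cc23)cc1`) gives 24900 nM as the higher of the two numbers, which is a 7.1-fold higher number from compound 1 to compound 2 (0.85 log units; beyond the scatter) with dimethylamino in place of hydroxy on an aromatic carbon. Compound 3 (`Brc1ccc(C(c2c[nH]c3ccc(Br)cc23)c2c[nH]c3ccc(Br)cc23)cc1`) has bromo in place of dimethylamino on an aromatic carbon, para to a large group, and bromo in place of dimethylamino on an aromatic carbon counts this change from 4-(dimethylamino)phenyl to 4-bromophenyl. Within the data shown here, only one measured step bears on it, with dimethylamino entering where it now leaves, and no measured compound yet carries bromo there. Among the measured compounds shown here, a modest move to a lower number in this assay is expected, because a 7.1-fold higher number from compound 1 to compound 2 (0.85 log units; beyond the scatter) is the only measured guide. The expected move is a 3.1-fold lower number from compound 2 to compound 3 (0.49 log units; beyond the scatter) and remains an estimate. For compound 3 the estimate is 8000 nM with an expected range of 2500 nM to 25000 nM in this series.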

Compound 3, half-maximal inhibitory concentration: 3200 nM
Compound 3: middle estimate off by 2.5-fold (0.40 log units), on the high side; the measured number falls inside the stated range.
By their numbers in this assay, from the lowest: compounds 3 and 1 (each within the scatter of the next); then compound 2.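

In this assay, bromo in place of dimethylamino on the aromatic carbon para to a large group gives a 7.8-fold lower number from compound 2 to compound 3 (0.89 log units; beyond the scatter) and so the high number is not common to every replacement of hydroxy at this position. Bromo in place of hydroxy gives a 1.1-fold lower number from compound 1 to compound 3 (0.04 log units; within the scatter) and leaves the two groups indistinguishable on this read-out, so of the three groups shown only dimethylamino stands apart. No measurement offers an explanation for either step.

The compounds shown leave open how a primary amine, a methoxy group or a carboxylic acid would read at this position. On these data alone, it also remains open whether the gap between dimethylamino and the other two groups persists on a core that lacks the two bromo groups of the shared core.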